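Removing the chloro from compound 2

The source may hold more compounds than are shown below. What is called first, only, known or untested is meant among the compounds shown, and "the series" means these compounds.

For the measured compounds named here, in a functional assay on HepG2 cells (Homo sapiens) for antiproliferative activity, read by MTT assay, with a stated time of 72 h (a higher number here means a weaker inhibitor, a lower number a stronger inhibitor), compound 2 `O=C1COc2ccc(-c3cnc4ccccc4c3)cc2N1c1ccc(Cl)cc1` gives 32700 nM, the only actual number so far. Compound 1 `Cc1ccc(N2C(=O)COc3ccc(-c4cnc5ccccc5c4)cc32)cc1` reads > 40000 nM in this assay, and this is a limit, not a number.

Compound 3 `O=C1COc2ccc(-c3cnc4ccccc4c3)cc2N1c1ccccc1` carries hydrogen in place of chloro on an aromatic carbon, para to a large group, which turns 4-chlorophenyl into phenyl: hydrogen in place of chloro on an aromatic carbon.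

Going by the values given here, only one measured step bears on this change, also at an aromatic carbon: chloro in place of methyl, an at least 1.2-fold lower number from compound 1 to compound 2 (0.08 log units; that floor lies within the scatter). As far as these compounds go, that step rests on (the limit of > 40000 nM in this assay, at which 1 of the 2 values shown sits), so its true size is unknown and it gives no firm direction for a further change. With so little to go on, no shift beyond the scatter is expected in this assay.

The expected result is a 1.1-fold higher number from compound 2 to compound 3 (0.04 log units; within the scatter), an estimate that stays within the scatter. For compound 3 the estimated value is 36000 nM, with an expected range from 20000 nM to 60000 nM. A reading reported only as a limit is also a realistic expectation for compound 3.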

Compound 3, half-maximal inhibitory concentration: > 40000 nM
Compound 3 gave a limit, no number (the forecaster's own chance of this, stated with the estimate: 40%); middle value at least 1.1-fold (0.04 log units) away from the limit.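

In this assay compound 3 reads > 40000 nM, a limit and not a number. The change from 4-chlorophenyl to phenyl gives an at least 1.2-fold higher number from compound 2 to compound 3 (0.08 log units; that floor lies within the scatter), so the true size of the change remains unknown, and the chloro is shown neither to matter nor to be dispensable on this aromatic carbon. Compound 1 and compound 3 are both limits, so the step between them cannot be read, and hydrogen, methyl and chloro at this position fall into no readable order: the limit of > 40000 nM in this assay, at which 2 of the 3 values shown sit.

For the compounds shown here, compound 2, at 32700 nM, remains the only actual number in this assay, which leaves open whether any group at this position can give a value clearly separated from it. As far as these compounds go, an amine, a carboxylic acid or a longer alkyl chain on this aromatic carbon would test that question, and whether changes elsewhere on the shared core would bring the series away from the limit also remains open.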